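The compounds below may be only part of what the source reports. "The series", "measured", "known", "first", "only" and "open" are said of these compounds alone.

Measured in an ADME assay on MRC5 cells (Homo sapiens) for inhibition, read by MTT assay, with a stated time of 72 h; on this read-out lower numbers stand for stronger inhibition and higher numbers for weaker inhibition:

- compound 1 `O=C(OCCCCCCCCO)OCCc1ccc(O)c(O)c1`: > 50000 nM (a limit of the assay)
- compound 2 `CCCCOC(=O)OCCc1ccc(O)c(O)c1`: "not determined" (no result reported)
- compound 3 `CCCCCCOC(=O)OCCc1ccc(O)c(O)c1`: 11200 nM

Among these three compounds, only compound 3 has an actual number, 11200 nM, in this assay. Compound 1 sits at a limit, and the limit of > 50000 nM in this assay, at which 1 of the 3 values shown sits, is the only such case here. Compound 2 offers no result for comparison.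

The next compound is compound 4 `CCCCCCCCCCCCOC(=O)OCCc1ccc(O)c(O)c1`, and the change is hexyl in place of hydrogen on a saturated chain carbon, six bonds along the chain from an oxygen next to a carbonyl group.

For the measured compounds named here, only one measured step bears on this carbon. That step, an at least 4.4-fold lower number from compound 1 to compound 3 (0.64 log units; beyond the scatter), goes beyond the scatter, but it puts hydrogen in place of 2-hydroxyethyl, whereas the new change puts hexyl in place of hydrogen. It therefore gives only weak guidance, and compound 2 adds no shorter-chain reference point. A small shift toward a lower number is expected in this assay, but no step beyond the scatter is firmly expected. The estimate implies a 1.4-fold lower number from compound 3 to compound 4 (0.15 log units; within the scatter), and this expected step stays modest. For compound 4 the estimated value is 8000 nM, with an expected range from 2500 nM to 30000 nM.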

Compound 4, half-maximal inhibitory concentration: 12400 nM
Estimate against measurement, compound 4: 1.6-fold (0.19 log units) below; measured number inside the range.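

In this assay, putting hexyl in place of hydrogen on a saturated chain carbon, six bonds along the chain from an oxygen next to a carbonyl group, gives a 1.1-fold higher number from compound 3 to compound 4 (0.04 log units; within the scatter), so the added carbons produce no change that can be told from the scatter. This is the first step shown that extends the plain chain itself, and it makes compound 3 and compound 4 equivalent in this assay. Butyl in place of hydroxy on a saturated chain carbon, eight bonds along the chain from an oxygen next to a carbonyl group, gives an at least 4.0-fold lower number from compound 1 to compound 4 (0.60 log units; beyond the scatter), but compound 1 stands at a limit of the assay, so this step sets only a bound on the difference: the limit of > 50000 nM in this assay, at which 1 of the 4 values shown sits.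

As far as these compounds go, compound 2, with its butyl chain, has no reported result, so it remains open whether the number stays level for a chain shorter than hexyl, and a longer chain than that of compound 4 could still move it either way. Also open is what an amine or a carboxylic acid at the chain end would do, as the only polar chain end shown is the hydroxy of compound 1.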